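A few compounds are considered here, and "the series" means these few. Any claim that something is new, unique, unknown or untested is made for them only; others in the source may bear on it.

Compound 1 `COC(=O)c1sc2cc(-c3ccoc3)cnc2c1N` bears a furan-3-yl group on its core. In a functional assay on MCF7 cells (Homo sapiens) for inhibition, read by sulforhodamine B assay, with a stated time of 48 h (a lower number here means a stronger inhibitor of growth, a higher number a weaker inhibitor of growth), compound 1 gives > 120000 nM, which is a limit of the assay rather than a measured number. For the measured compounds named here, compound 2 `COC(=O)c1sc2cc(-c3cnc(OC)nc3OC)cnc2c1N` is the only other compound with a value here. In this assay compound 2 gives > 75000 nM, again a limit and not a number. Going by the values given here, compound 1 therefore cannot be ranked against compound 2 at all: one value sits at the limit of > 120000 nM in this assay, at which 1 of the 2 values shown sits, and the other at the limit of > 75000 nM in this assay, at which 1 of the 2 values shown sits, and no step between measured compounds is available.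

Compound 3 `COC(=O)c1sc2cc(-c3ccc(N)cc3)cnc2c1N` differs from compound 1 in one place: 4-aminophenyl in place of furan-3-yl on an aromatic carbon. With nothing measured for this change, the size of the step in this assay is uncertain, and a step beyond the scatter is not expected to emerge from two limits. Compound 3 is expected to give about 60000 nM, in the range 8000 nM to 200000 nM. The expected step of an at least 2.0-fold lower number from compound 1 to compound 3 (0.30 log units; that floor lies within the scatter) is at most a small gain.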

Compound 3, concentration for 50% growth inhibition: 108000 nM
Compound 3: the middle estimate sits 1.8-fold (0.26 log units) below what was measured; low and high end bracket the measured number.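

For the compounds shown here, at this position on the shared core, compound 3 gives the first actual number in this assay, 108000 nM, so the change to 4-aminophenyl leaves a growth inhibition that can be read as a value. The change amounts to an at least 1.1-fold lower number from compound 1 to compound 3 (0.04 log units; that floor lies within the scatter), and no gain beyond the scatter can be claimed for it. The true size of the step stays unsettled because compound 1 carries a limit and not a number: the limit of > 120000 nM in this assay, at which 1 of the 3 values shown sits.

On these data alone, what a plain phenyl or a 4-hydroxyphenyl group would give at this position remains open, and with it whether the amine on the ring counts at all. Also open, as far as these compounds go, is whether a carboxylic acid or an amide in place of the methyl ester would change the number.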